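The source may hold more compounds than are shown below. What is called first, only, known or untested is meant among the compounds shown, and "the series" means these compounds.

Measured so far:
compound 1 `CC1CCC(=O)N1CC#CCn1ccnc1`, 1.1 mg/kg
compound 2 `Cc1cncn1CC#CCN1C(=O)CCC1C`, 1.4 mg/kg
compound 3 `Cn1ccn(CC#CCn2ccnc2)c1=O`, a limit of > 100 mg/kg

Compound 1 and compound 2 share a core and differ in one place. In a functional assay on the whole organism for antagonist activity, with Mus musculus as the target (on this read-out lower numbers stand for an effect already at smaller amounts and higher numbers for an effect only at larger amounts of compound), compound 1 gives 1.1 mg/kg. The change between them is methyl in place of hydrogen on an aromatic carbon and it moves the number by a 1.3-fold higher number from compound 1 to compound 2 (0.10 log units; within the scatter), so the two compounds cannot be told apart in this assay. Compound 3 carries a different core; how it differs from the core of compound 1 is not broken down here. In this assay compound 3 returns only a limit, > 100 mg/kg, as told by the limit of > 100 mg/kg in this assay, at which 1 of the 3 values shown sits, and no number is known for it.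

Compound 4 `Cc1cncn1CC#CCn1ccn(C)c1=O` has not been measured in this assay. Going by the values given here, it stands to compound 3 as compound 2 stands to compound 1: the change is methyl in place of hydrogen on an aromatic carbon, the same change as the one between compound 1 and compound 2. Since that change moved the number by a 1.3-fold higher number from compound 1 to compound 2 (0.10 log units; within the scatter), the step from compound 3 to compound 4 is expected to be small as well, roughly a step that the limit leaves unreadable from compound 3 to compound 4. Compound 4 is therefore estimated to sit near 150 mg/kg, between 50 mg/kg and 500 mg/kg, and it is expected that this assay will most likely again report only a limit for compound 4 rather than a number.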

Compound 4, dose for half-maximal effect: 22 mg/kg
The estimate for compound 4 lay 6.8-fold (0.83 log units) above the measured number; measured number outside the range, below it.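

The same swap, methyl in place of hydrogen on an aromatic carbon, does not have the same outcome on both cores in this assay, so its effect on one core could not simply be transferred to the other: the same change on two cores in this assay, a 1.3-fold higher number (0.10 log units; within the scatter) from compound 1 to compound 2 and an at least 4.5-fold lower number (0.65 log units; beyond the scatter) from compound 3 to compound 4, at least 5.7-fold (0.76 log units) apart, beyond the scatter of two such steps On the core of compound 3, the swap gives an at least 4.5-fold lower number from compound 3 to compound 4 (0.65 log units; beyond the scatter), which means that this small change is linked to a readable gain on this core, whereas on the core of compound 1 it leaves the two compounds indistinguishable. The value of compound 3, > 100 mg/kg, is a limit and not a number, so the full size of the step remains unknown, and a comparison of two cores cannot explain why the outcomes differ or predict the outcome on a third core.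

The compounds shown carry only hydrogen or methyl at this aromatic carbon, so it remains open whether an ethyl group, a chlorine atom or a methoxy group there would also separate the two cores. The chain linking the two ends of the molecule is also the same throughout, leaving open how a longer chain would affect the result on either core.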